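From 4-methylpiperazin-1-yl to piperazin-1-yl in compound 2

The compounds below may be only part of what the source reports. "The series", "measured", "known", "first", "only" and "open" are said of these compounds alone.

In an ADME assay on microsomes from liver (Mus musculus) for metabolic stability, read by LC-MS, with a stated time of 10 min (on this read-out higher numbers stand for a more stable compound and lower numbers for a less stable compound), compound 1 `CCN(C[C@H]1Cc2c(cccc2N2CCNCC2)CN1)[C@H]1CCCc2cccnc21` gives 53.8% while compound 2 `CN1CCN(c2cccc3c2C[C@H](CN(C)[C@H]2CCCc4cccnc42)NC3)CC1` gives 17% as the lower of the two numbers, a gap beyond the scatter. Compound 3 `CN(C[C@H]1Cc2c(cccc2N2CCNCC2)CN1)[C@H]1CCCc2cccnc21` is still unmeasured and differs from compound 2 by hydrogen in place of methyl on an amine nitrogen in a ring. For the measured compounds named here, no measured pair shows this change alone, so any expectation is loose. A rise beyond the scatter is expected in this assay with the estimated step of a number 25 percentage points higher from compound 2 to compound 3 (beyond the scatter) as a rough guide. Going by the values given here, the expectation leans on compound 1 at 53.8% as the only higher number. For compound 3 the estimate is 42% with an expected range from 22% to 65% on this read-out.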

Compound 3, percent of the compound remaining: 19.9%
Compound 3: the middle estimate sits 22.1 percentage points above what was measured; measured number below the stated range.
By their numbers in this assay, from the lowest: compounds 2 and 3 (each within the scatter of the next); then compound 1.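

Swapping 4-methylpiperazin-1-yl for piperazin-1-yl does not move this assay beyond the scatter, with a number 2.9 percentage points higher from compound 2 to compound 3 (within the scatter). Hydrogen in place of methyl on a saturated chain carbon bound to an amine nitrogen, with piperazin-1-yl held constant, gives a number 33.9 percentage points lower from compound 1 to compound 3 (beyond the scatter), so the chain carbon is the place where the read-out responds in these compounds. Nothing available explains either step.

Going by these compounds, whether an acetyl group or a longer chain on the amine nitrogen in the ring would also leave the number within the scatter remains open. So does the effect of a propyl group on the chain amine nitrogen.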